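From 4-chlorophenyl to 3-chlorophenyl: working estimate

The compounds below may be only part of what the source reports. "The series", "measured", "known", "first", "only" and "open" are said of these compounds alone.

Measured in a functional assay on MDA-MB-231 cells (Homo sapiens) for inhibition, read by MTT assay, with a stated time of 72 h; a higher number here means a weaker inhibitor, a lower number a stronger inhibitor:
- compound 1 `O=[N+]([O-])c1cccc(Nc2nnc(-c3c[nH]c4ccccc34)o2)c1`: 34600 nM
- compound 2 `O=[N+]([O-])c1ccc(Nc2nnc(-c3c[nH]c4ccccc34)o2)cc1`: 3540 nM
- compound 3 `Clc1ccc(Nc2nnc(-c3c[nH]c4ccccc34)o2)cc1`: 9770 nM

Compound 3 stands second highest of the three numbers, with compound 2 lower and compound 1 higher. The next entry is compound 4 `Clc1cccc(Nc2nnc(-c3c[nH]c4ccccc34)o2)c1`, which carries 3-chlorophenyl in place of 4-chlorophenyl on a nitrogen on an aromatic ring. Going by the values given here, the only measured single-place step, a 2.8-fold higher number from compound 2 to compound 3 (0.44 log units; beyond the scatter), exchanges nitro for chloro and does not move a group, so it bears on this change only indirectly. The closest evidence is the pair of nitro compounds, where the group sits in two different places. There compound 2 gives 3540 nM and compound 1 gives 34600 nM, a clearly higher number. That is a single pair with a different group, so the same direction is expected here, with a smaller step and wide uncertainty. In this assay the expected change is a 2.3-fold higher number from compound 3 to compound 4 (0.35 log units; beyond the scatter), toward a weaker inhibitor. For compound 4 the estimated value is 22000 nM, with an expected range of 7000 nM to 60000 nM for a measurement.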

Compound 4, half-maximal inhibitory concentration: 8890 nM
Compound 4: the middle estimate sits 2.5-fold (0.39 log units) above what was measured; the range from low to high includes it.
By their numbers in this assay, from the lowest: compound 2; then compounds 4 and 3 (each within the scatter of the next); then compound 1.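

With chloro as the group, 3-chlorophenyl in place of 4-chlorophenyl on the nitrogen makes no readable difference in this assay, a 1.1-fold lower number from compound 3 to compound 4 (0.04 log units; within the scatter), whereas the nitro pair printed far apart, with compound 2 at 3540 nM and compound 1 at 34600 nM. The sensitivity to this change seen with nitro therefore does not extend to chloro, and this position cannot be treated as uniformly intolerant or tolerant across the two groups. Chloro in place of nitro also gains a second reading, a 3.9-fold lower number from compound 1 to compound 4 (0.59 log units; beyond the scatter), and its direction is opposite to the earlier step, so the value of that exchange depends on where the group sits: the two readings do not agree, and no single figure for the exchange can be carried across the series: the same change on two cores in this assay, a 2.8-fold higher number (0.44 log units; beyond the scatter) from compound 2 to compound 3 and a 3.9-fold lower number (0.59 log units; beyond the scatter) from compound 1 to compound 4, 11-fold (1.03 log units) apart, beyond the scatter of two such steps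

From the compounds shown here alone, the series still rests on one pair for each group, and it remains open which of the two pairs is the more typical. A methoxy group, an amine or a carboxylic acid on the same ring, in both placements, would show whether the gap between the nitro compounds is the exception or the rule.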